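The compounds below may be only part of what the source reports. "The series", "measured", "known", "first", "only" and "open" are said of these compounds alone.

Within the data shown here, in a functional assay on MOLT-4 cells (Homo sapiens) for antiproliferative activity, read by cell counting, with a stated time of 2 days (on this read-out higher numbers stand for weaker inhibition and lower numbers for stronger inhibition), compound 1 `COc1ccc(C(=O)c2sc(Nc3ccccc3)nc2N)cc1OC` gives 5500 nM, the higher of the two numbers measured so far. Compound 2 `COc1cccc(Nc2nc(N)c(C(=O)c3ccccc3)s2)c1` gives 1500 nM in this assay, a lower number that lies beyond the scatter. Among the measured compounds shown here, compound 2 differs from compound 1 in more than one place, so no single step joins them. Compound 3 `COc1cccc(C(=O)c2sc(Nc3ccccc3)nc2N)c1` differs from compound 1 in one place only: hydrogen in place of methoxy on an aromatic carbon. In this assay only a modest step is expected, a 1.6-fold lower number from compound 1 to compound 3 (0.20 log units; within the scatter), leaning toward a lower number. Compound 3 is estimated at 3500 nM, with a range from 1200 nM to 10000 nM.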

Compound 3, half-maximal inhibitory concentration: 1300 nM
Beside the measured number, compound 3's estimate is 2.7-fold (0.43 log units) above it; the measured number falls inside the stated range.
By their numbers in this assay, from the lowest: compounds 3 and 2 (each within the scatter of the next); then compound 1.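

In this assay, hydrogen in place of methoxy on the aromatic carbon para to a large group gives a 4.2-fold lower number from compound 1 to compound 3 (0.63 log units; beyond the scatter). Among these compounds, this is the first comparison here that isolates a single place, and it shows that the methoxy at this position is not needed for activity: the number improves once it leaves, while the other methoxy stays. Nothing available explains this difference. The compounds shown leave open how a hydroxyl, a chlorine or an amine would compare on this carbon, and what the remaining methoxy contributes.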